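This account rests on a few compounds, and the source may have more. Where it says the series, first, only, none or still open, it means among the compounds named here.

Compound 1 `O=S(=O)(c1ccc(F)cc1)c1cc(Cl)c(O)c2ncccc12`: 23%
Compound 2 `O=S(=O)(c1ccc(F)cc1)c1cc(F)c(O)c2ncccc12`: 100%
Compound 3 `Cc1ccc(S(=O)(=O)c2cc(F)c(O)c3ncccc23)cc1`: 34%

In an ADME assay on the whole organism for pharmacokinetics, with Rattus norvegicus as the target (a higher number here means that a larger share of the oral dose reaches the circulation, a lower number that a smaller share of the oral dose reaches the circulation), compound 1 stands lowest of the three at 23%. Compound 4 `O=S(=O)(c1cc(Cl)c(O)c2ncccc12)C1CCCC1` differs from it in one place: cyclopentyl in place of 4-fluorophenyl on a sulfonyl sulfur, with cyclopentyl in place of 4-fluorophenyl on a sulfonyl sulfur. Among the compounds with values here, no measured step makes this exchange. The closest is a number 66 percentage points lower from compound 2 to compound 3 (beyond the scatter), which alters the group on the sulfonyl sulfur, while a number 77 percentage points higher from compound 1 to compound 2 (beyond the scatter) leaves that group untouched. Both steps are large, so sizeable movement is possible, but neither indicates a direction for cyclopentyl. The expected result is therefore a number 5 percentage points higher from compound 1 to compound 4 (within the scatter), a step within the scatter but with wide uncertainty. Compound 4 is estimated at 28%, with an expected range of 8% to 60%.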

Compound 4, oral bioavailability: 37%
The estimate for compound 4 lay 9 percentage points below the measured number; measured number inside the range.
By their numbers in this assay, from the lowest: compound 1; then compounds 3 and 4 (each within the scatter of the next); then compound 2.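

With cyclopentyl in place of 4-fluorophenyl on the sulfonyl sulfur, this assay shows a number 14 percentage points higher from compound 1 to compound 4 (beyond the scatter) in a modest step. The earlier compounds shown here all carried a six-membered aromatic ring on that sulfur, whereas compound 4 shows that a five-membered non-aromatic carbon ring can stand there without a loss of oral bioavailability. No measurement at hand accounts for the rise. The compounds shown leave open whether cyclopentyl would act alike on the core of compound 2. They also leave open how a cyclohexyl ring, an open butyl chain or an amine would fare on that sulfur.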